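Adding a second methyl to compound 2

A few compounds are considered here, and "the series" means these few. Any claim that something is new, unique, unknown or untested is made for them only; others in the source may bear on it.

In an ADME assay on HepG2 2.2.15 cells (Homo sapiens) for cytotoxicity, read by CCK-8 assay, with a stated time of 8 days (on this read-out lower numbers stand for higher toxicity in this test and higher numbers for lower toxicity in this test), compound 1 `COc1ccc(-c2cc(NC(=O)c3ccccc3O)c[nH]c2=O)cc1` gives > 100000 nM, which is a limit of the assay. Compound 2 `Cc1cccc(-c2cc(NC(=O)c3ccccc3O)c[nH]c2=O)c1` gives 98800 nM, the higher of the two actual numbers, and compound 3 `Cc1cccc(-c2cc(NC(=O)c3ccc(C(F)(F)F)cc3O)c[nH]c2=O)c1` gives 24200 nM. Compound 4 `Cc1cc(C)cc(-c2cc(NC(=O)c3ccccc3O)c[nH]c2=O)c1` carries methyl in place of hydrogen on an aromatic carbon, 3-methylphenyl to 3,5-dimethylphenyl (methyl in place of hydrogen on an aromatic carbon). The change at this aryl group has one precedent, an at least 1.0-fold lower number from compound 1 to compound 2 (0.00 log units; that floor lies within the scatter), and that step rests on (the limit of > 100000 nM in this assay, at which 1 of the 3 values shown sits). For the measured compounds named here, the only step beyond the scatter, a 4.1-fold lower number from compound 2 to compound 3 (0.61 log units; beyond the scatter), adds trifluoromethyl at a different place and is modest. A small move to a lower number is therefore expected, probably within the scatter, as a 1.5-fold lower number from compound 2 to compound 4 (0.18 log units; within the scatter). For compound 4 the estimated value is 65000 nM, with an expected range of 28000 nM to 100000 nM.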

Compound 4, half-maximal cytotoxic concentration: 25100 nM
Compound 4: the middle estimate sits 2.6-fold (0.41 log units) above what was measured, and the stated range ends above it.
By their numbers in this assay, from the lowest: compounds 3 and 4 (each within the scatter of the next); then compound 2. At a limit, above all of these: compound 1.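

In this assay, the aryl group alone can now shift the number: the added methyl, meta to a methyl group, gives a 3.9-fold lower number from compound 2 to compound 4 (0.60 log units; beyond the scatter). The earlier change at this aryl group showed no readable shift. The series also shows an at least 3.9-fold lower number from compound 1 to compound 4 (0.60 log units; beyond the scatter), which is only a floor, as compound 1 stands at a limit: the limit of > 100000 nM in this assay, at which 1 of the 4 values shown sits.

Still open, from the compounds shown here alone, is whether an ethyl group or a chlorine atom at this place would move the number further. Also open, going by these compounds, is how 3,5-dimethylphenyl and trifluoromethyl behave together in one compound.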